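Carboxyphenyl tetrazole analogue expected near the ester's potency

The source may report more compounds than this note shows. Statements on the series, on what has been measured and on what is new or still open speak of the compounds shown alone.

Within the data shown here, compound 3 `CCCCCCCCc1ccc(OCC(=O)Cn2nnc(-c3ccncc3)n2)cc1` stands together with compound 1 `CCCCCCCCc1ccc(OCC(=O)Cn2nnc(-c3ccccc3)n2)cc1` at the lowest of the three numbers measured so far: in an assay on microsomes from brain for inhibition of Fatty-acid amide hydrolase 1 (Rattus norvegicus), read by fluorescence and HPLC, with a stated time of 60 min (a higher number here means a weaker inhibitor, a lower number a stronger inhibitor), compound 3 gives 24 nM, and compound 1 gives 24 nM. Compound 2 `CCCCCCCCc1ccc(OCC(=O)Cn2nnc(-c3ccc(C(=O)OC)cc3)n2)cc1` gives 29 nM in this assay. None of the three is separated from the others beyond the scatter, as seen in a 1.2-fold higher number from compound 1 to compound 2 (0.08 log units; within the scatter), no change at the digits printed from compound 1 to compound 3 (within the scatter) and a 1.2-fold lower number from compound 2 to compound 3 (0.08 log units; within the scatter).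

Compound 4 `CCCCCCCCc1ccc(OCC(=O)Cn2nnc(-c3ccc(C(=O)O)cc3)n2)cc1` is not yet measured. It differs from compound 3 by 4-carboxyphenyl in place of pyridin-4-yl on an aromatic carbon. Among the measured compounds shown here, the steps that bear on this change are the replacement of a hydrogen by methoxycarbonyl, a 1.2-fold higher number from compound 1 to compound 2 (0.08 log units; within the scatter), and the exchange of the 4-(methoxycarbonyl)phenyl group for pyridin-4-yl, a 1.2-fold lower number from compound 2 to compound 3 (0.08 log units; within the scatter), both within the scatter. Since the group that enters in compound 4 shares its ring with that of compound 2, a step no larger than the scatter, or at most a small rise in the number, is expected in this assay. Compound 4 is therefore estimated at 45 nM, with a range of 15 nM to 150 nM, which corresponds to the expected step of a 1.9-fold higher number from compound 3 to compound 4 (0.27 log units; within the scatter).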

Compound 4, half-maximal inhibitory concentration: 90 nM
Compound 4: the middle estimate sits 2.0-fold (0.30 log units) below what was measured, and the stated range covers the measured number.
By their numbers in this assay, from the lowest: compounds 1, 3 and 2 (each within the scatter of the next); then compound 4.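

In this assay, among these compounds, the carboxy group is the first change at this position to lie beyond the scatter, with a 3.8-fold higher number from compound 1 to compound 4 (0.57 log units; beyond the scatter) where methoxycarbonyl had made no such separation from hydrogen. Replacing the methyl on the oxygen with hydrogen gives a 3.1-fold higher number from compound 2 to compound 4 (0.49 log units; beyond the scatter) so a change of one small group within the substituent separates two compounds that the same aromatic position otherwise shares. Exchanging pyridin-4-yl for 4-carboxyphenyl gives a 3.8-fold higher number from compound 3 to compound 4 (0.57 log units; beyond the scatter) and all three steps are modest.

The compounds shown leave open whether a primary amide or a hydroxymethyl group in place of carboxy would read nearer compound 2 or compound 4. They also leave open whether an ethyl ester would stay level with the methyl ester, and nothing available explains the rise seen with the carboxy group.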